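Replacing a Ring Hydrogen with 3-Chlorobenzyl

The source may hold more compounds than are shown below. What is called first, only, known or untested is meant among the compounds shown, and "the series" means these compounds.

Compound 1 `CN(C)Cc1ccc2nc(NC(=O)N/N=C3\C(=O)Nc4ccc(F)cc43)sc2c1`: 2310 nM
Compound 2 `CC1CCN(Cc2ccc3nc(NC(=O)N/N=C/c4cn(Cc5cccc(Cl)c5)c5ccccc45)sc3c2)CC1`: 2810 nM
Compound 3 `CCN(CC)Cc1ccc2nc(NC(=O)N/N=C/c3c[nH]c4ccccc34)sc2c1`: 3300 nM

Of the compounds shown here, three have been measured in a functional assay on A549 cells (Homo sapiens) for cytotoxicity, read by MTT assay, with a stated time of 72 h; on this read-out higher numbers stand for weaker inhibition and lower numbers for stronger inhibition. Compound 3 gives 3300 nM, the highest of the three numbers. Compound 2 gives 2810 nM and compound 1 gives 2310 nM; both lie within the usual scatter of the value of compound 3, so none of the three can be set apart from the others on these numbers.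

Compound 4 `CCN(CC)Cc1ccc2nc(NC(=O)N/N=C/c3cn(Cc4cccc(Cl)c4)c4ccccc34)sc2c1` has not yet been measured. It differs from compound 3 in one place: 3-chlorobenzyl in place of hydrogen on an aromatic nitrogen. Compound 2 carries the same 3-chlorobenzyl group on an aromatic nitrogen, with a different amine on the other end of the molecule, and in this assay compound 2 gives 2810 nM, close to compound 3. On this basis the step of a 1.2-fold lower number from compound 3 to compound 4 (0.07 log units; within the scatter) is expected to be small, in either direction and not beyond the scatter. Compound 4 is estimated at 2800 nM, with a likely range from 1200 nM to 6500 nM.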

Compound 4, half-maximal inhibitory concentration: 2410 nM
Compound 4: the middle estimate sits 1.2-fold (0.07 log units) above what was measured, and the stated range covers the measured number.
By their numbers in this assay, from the lowest: compounds 1, 4, 2 and 3 (each within the scatter of the next).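

In this assay, the change on the aromatic nitrogen can now be read on its own: 3-chlorobenzyl in place of hydrogen gives a 1.4-fold lower number from compound 3 to compound 4 (0.14 log units; within the scatter). This position therefore takes the whole group, with its six-membered aromatic ring of carbon only, without a step that can be told from the scatter. Among these compounds, the other end of the molecule can also be read for the first time: diethylamino in place of 4-methylpiperidin-1-yl gives a 1.2-fold lower number from compound 2 to compound 4 (0.07 log units; within the scatter).

No measured evidence bearing on these steps is available.

Going by these compounds, it remains open whether a methyl group or an unsubstituted benzyl group on this nitrogen would also stay within the scatter. The same question stands for a benzyl group carrying a carboxylic acid or an amine in place of the chlorine.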